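The source may hold more compounds than are shown below. What is called first, only, known or untested is meant among the compounds shown, and "the series" means these compounds.

Compound 3 `CCCCN(O)C(=O)Nc1cc([C@@H]2CC[C@@H](c3cc(OC)c(OC)c(OC)c3)O2)cc(OC)c1OCCS(=O)(=O)c1ccc(Br)cc1` stands highest of the three measured compounds in a functional assay on the whole organism for inhibition, with Mus musculus as the target, at a dose of 3 mg/kg (a higher number here means more inhibition at the dose given (going by the name of the read-out), a lower number less inhibition), where compound 3 gives 35%. Compound 4 `CCCCN(O)C(=O)Nc1cc([C@@H]2CC[C@@H](c3cc(OC)c(OC)c(OC)c3)O2)cc(OC)c1OCCSc1ccc(OC)cc1` has not yet been measured. Its change from compound 3 is (4-methoxyphenyl)sulfanyl in place of (4-bromophenyl)sulfonyl on a saturated chain carbon, two bonds along the chain from an oxygen on an aromatic ring. For the measured compounds named here, two measured steps bear on this change. The first, a number 32 percentage points higher from compound 1 to compound 3 (beyond the scatter), separates compound 1 `CCCCN(O)C(=O)Nc1cc([C@@H]2CC[C@@H](c3cc(OC)c(OC)c(OC)c3)O2)cc(OC)c1OCCSc1ccc(Br)cc1` with 3% from compound 3, and compound 4 reverses that part of the change, so a drop of similar size is expected. The second, a number 23 percentage points higher from compound 2 to compound 3 (beyond the scatter), separates compound 2 `CCCCN(O)C(=O)Nc1cc([C@@H]2CC[C@@H](c3cc(OC)c(OC)c(OC)c3)O2)cc(OC)c1OCCS(=O)(=O)c1c(F)c(F)cc(F)c1F` with 12% from compound 3 and shows that the ring on the sulfonyl sulfur also matters. Compound 4 is therefore expected to give 6%, between 0% and 20%, a step of a number 29 percentage points lower from compound 3 to compound 4 (beyond the scatter).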

Compound 4, a percentage reported as inhibition, in the whole organism at one dose (the size of the read-out at that dose, not a potency): 3%
Compound 4: the middle estimate sits 3 percentage points above what was measured, within the range that was stated.
By their numbers in this assay, from the lowest: compounds 1, 4 and 2 (each within the scatter of the next); then compound 3.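

With the sulfanyl link, methoxy and bromo on the aromatic ring cannot be told apart in this assay, which shows no change at the digits printed from compound 1 to compound 4 (within the scatter) here. The full swap gives a number 32 percentage points lower from compound 3 to compound 4 (beyond the scatter), the same size as the step seen when only the sulfonyl becomes sulfanyl, so the ring substituent adds nothing readable on top of that. No measurement here gives a reason for this. As far as these compounds go, it remains open whether methoxy would also match bromo on the sulfonyl compounds, where the ring did matter. An amine or a carboxylic acid on that ring could also behave differently.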